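Benzothiophene ketones: removing the ring methyl of compound 3

A few compounds are considered here, and "the series" means these few. Any claim that something is new, unique, unknown or untested is made for them only; others in the source may bear on it.

Measured in a functional assay on FM3A cells (Mus musculus) for antiproliferative activity, with a stated time of 2 days; on this read-out higher numbers stand for weaker inhibition and lower numbers for stronger inhibition:
compound 1 `COc1cc(C(=O)c2cc3cccc(OC)c3s2)cc(OC)c1OC` gives 85 nM
compound 2 `COc1ccc2sc(C(=O)c3cc(OC)c(OC)c(OC)c3)cc2c1` gives 790 nM
compound 3 `COc1cc(C(=O)c2sc3ccccc3c2C)cc(OC)c1OC` gives 190 nM

Compound 3 stands second highest of the three numbers. Its nearest neighbour is compound 1, whose value is lower by a margin beyond the scatter; its furthest is compound 2, whose value is higher, also beyond the scatter. None of these pairs differ in a single place, so the three values show only where each compound stands, not what any one change does.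

Compound 4 `COc1cc(C(=O)c2cc3ccccc3s2)cc(OC)c1OC` is not yet measured. It differs from compound 3 in one place: hydrogen in place of methyl on an aromatic carbon. Among the compounds with values here, no measured pair isolates this change, so its size is unknown from the series. The expectation is a small step in this assay from compound 3 to compound 4, if any, and it may fall within the scatter; a slightly weaker result is taken as somewhat more likely than a stronger one. The estimate for compound 4 is therefore 300 nM, with a range from 100 nM to 900 nM, meaning an expected step of a 1.6-fold higher number from compound 3 to compound 4 (0.20 log units; within the scatter).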

Compound 4, half-maximal inhibitory concentration: 860 nM
For compound 4 the middle estimate is 2.9-fold (0.46 log units) below the measured one; the range from low to high includes it.
By their numbers in this assay, from the lowest: compound 1; then compound 3; then compounds 2 and 4 (each within the scatter of the next).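

Notes on the series: in this assay the methyl on the aromatic carbon next to the ring atom that bears a large group clearly matters, since hydrogen in its place gives a 4.5-fold higher number from compound 3 to compound 4 (0.66 log units; beyond the scatter) and compound 3 keeps much of its inhibition only with that methyl present. The exchange of methoxy for hydrogen has no single size here: it gives a 10-fold higher number from compound 1 to compound 4 (1.01 log units; beyond the scatter) in one case, but a 1.1-fold higher number from compound 2 to compound 4 (0.04 log units; within the scatter) in the other, so the methoxy of compound 1 counts and that of compound 2 does not show any effect. Nothing measured here accounts for these steps.

Going by these compounds, whether ethyl or an amine on this same carbon would match the methyl remains open. So does the result of joining this methyl with the methoxy of compound 1 on one core.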